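Butyl Urea Expected to Bind Tighter Than Dimethoxyphenyl Urea

A few compounds are considered here, and "the series" means these few. Any claim that something is new, unique, unknown or untested is made for them only; others in the source may bear on it.

Two compounds have so far been measured in an assay on isolated protein for inhibition of histamine H2 receptor (Cavia porcellus); on this read-out higher numbers stand for weaker binding and lower numbers for tighter binding:
- compound 1 `O=C(NCCCOc1cccc(CN2CCCCC2)c1)NCc1ccccc1` gives 347 nM
- compound 2 `COc1ccc(NC(=O)NCCCOc2cccc(CN3CCCCC3)c2)c(OC)c1` gives 2240 nM

Compound 2 stands at the higher of the two numbers, that is, it is the weaker binder of the pair. Among the measured compounds shown here, its only neighbour is reached by a 6.5-fold higher number from compound 1 to compound 2 (0.81 log units; beyond the scatter), a step in which 2,4-dimethoxyphenyl took the place of benzyl on an amide-type nitrogen and binding became weaker.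

Compound 3 `CCCCNC(=O)NCCCOc1cccc(CN2CCCCC2)c1` is the next variation on the same urea nitrogen: butyl in place of 2,4-dimethoxyphenyl on an amide-type nitrogen. For the measured compounds named here, the one measured step that bears on this change is a 6.5-fold higher number from compound 1 to compound 2 (0.81 log units; beyond the scatter): it showed that swapping a benzyl for the dimethoxyphenyl ring cost binding. Compound 3 now removes that ring and its two acceptors altogether and puts in a plain butyl chain, a group that in kind sits nearer to the benzyl of compound 1 than to the aryl of compound 2. The number is therefore expected to move back toward that of compound 1, giving a 3.7-fold lower number from compound 2 to compound 3 (0.57 log units; beyond the scatter) in this assay. Going by the values given here, no measured compound shows how a chain without any ring compares with benzyl, so the range is kept wide. For compound 3 the estimate in this assay is 600 nM, with a likely span from 200 nM to 2500 nM.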

Compound 3, dissociation constant: 81.3 nM
Compound 3: the middle estimate sits 7.4-fold (0.87 log units) above what was measured, and the stated range ends above it.
By their numbers in this assay, from the lowest: compound 3; then compound 1; then compound 2.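

In this assay the urea nitrogen needs no ring for tight binding: butyl in place of 2,4-dimethoxyphenyl brings a 28-fold lower number from compound 2 to compound 3 (1.44 log units; beyond the scatter) and is the largest step seen so far. The earlier pair showed only that benzyl bound tighter than 2,4-dimethoxyphenyl, which left open whether an aromatic ring at this place helped binding, but the comparison with the benzyl compound now gives a 4.3-fold lower number from compound 1 to compound 3 (0.63 log units; beyond the scatter) as propyl replaces phenyl on a saturated chain carbon bound to an amide-type nitrogen. That makes compound 3, with its plain chain, the tightest binder of the three, with both of its steps beyond the scatter, though no measurement shown here explains why binding changes in this way.

The compounds shown do not separate the effect of the two methoxy groups from that of the aromatic ring they sit on, and a plain phenyl on the same nitrogen would make that comparison possible. They also leave open how far the trend toward a simple chain extends, for instance to a longer chain such as hexyl or to a saturated ring such as cyclohexyl.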